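Swapping an amine tail for a carbamoyl group

The source may hold more compounds than are shown below. What is called first, only, known or untested is meant among the compounds shown, and "the series" means these compounds.

Compound 3 `NCCCC[C@H](NC(=O)CN(c1nc(Cl)nc2[nH]cnc12)C1CC1)C(=O)OCc1ccccc1` gives 9.88% in a functional assay on the whole organism (Tail, strain ICR) with Mus musculus as the target, in the tail flick test, with a stated time of 150 min, at a dose of 25 umol/kg by the oral route (a higher number here means a stronger effect of the compound at the dose given, a lower number a weaker effect), the second highest of three numbers. Compound 2 `N=C(N)NCCC[C@H](NC(=O)CN(c1nc(Cl)nc2[nH]cnc12)C1CC1)C(=O)OCc1ccccc1` gives 6.12%, and a number 3.8 percentage points higher from compound 2 to compound 3 (within the scatter). Compound 1 `C[C@H](NC(=O)CN(c1nc(Cl)nc2[nH]cnc12)C1CC1)C(=O)OCc1ccccc1` gives 23%, and a number 13.1 percentage points lower from compound 1 to compound 3 (beyond the scatter). Compound 4 `NC(=O)C[C@H](NC(=O)CN(c1nc(Cl)nc2[nH]cnc12)C1CC1)C(=O)OCc1ccccc1` differs from compound 3 by carbamoyl in place of 3-aminopropyl on a saturated chain carbon, two bonds along the chain from an amide-type nitrogen and a carbonyl carbon. Going by the values given here, the steps that bear on this are those adding a chain at the same place: a number 16.9 percentage points lower from compound 1 to compound 2 (beyond the scatter) and a number 13.1 percentage points lower from compound 1 to compound 3 (beyond the scatter); each chain lowered the read-out modestly against the hydrogen of compound 1. Compound 4 carries a shorter chain, so a small rise toward compound 1 is expected, and the expected step is a number 5.1 percentage points higher from compound 3 to compound 4 (within the scatter). Compound 4 is therefore estimated at 15%, in a range from 5% to 27%.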

Compound 4, a percentage reported as activity, at one dose (the size of the read-out at that dose, not a potency): 13.5%
For compound 4 the middle estimate is 1.5 percentage points above the measured one, within the range that was stated.
By their numbers in this assay, from the lowest: compounds 2, 3, 4 and 1 (each within the scatter of the next, the first and the last beyond it).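

Carbamoyl on this saturated chain carbon cannot be told apart from the longer chains in this assay: a number 3.6 percentage points higher from compound 3 to compound 4 (within the scatter) and a number 7.4 percentage points higher from compound 2 to compound 4 (within the scatter). It also stays within the scatter of the hydrogen in compound 1, with a number 9.5 percentage points lower from compound 1 to compound 4 (within the scatter), whereas compound 2 and compound 3 both lie beyond the scatter of compound 1. Nothing here gives a reason for these numbers.

As far as these compounds go, whether a carboxylic acid in place of carbamoyl, or the longer carbamoylethyl chain, would read closer to compound 1 or to compound 2 remains open.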